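Aryl swap at the exocyclic carbon: notes on compound 3

The source may report more compounds than this note shows. Statements on the series, on what has been measured and on what is new or still open speak of the compounds shown alone.

Measured so far in a functional assay on HeLa cells (Homo sapiens) for inhibition, read by MTT assay; a higher number here means a weaker inhibitor, a lower number a stronger inhibitor:
compound 1 `COc1ccc(/C=C2/N=C(c3ccccc3)N(c3ccc4oc(-c5ccccc5)cc(=O)c4c3)C2=O)cc1` gives 14.2 ug/mL
compound 2 `O=C1/C(=C\c2ccc(Cl)c(Cl)c2)N=C(c2ccccc2)N1c1ccc2oc(-c3ccccc3)cc(=O)c2c1` gives 15.2 ug/mL

For the measured compounds named here, compound 2 holds the larger of the two numbers so far, but the only neighbouring step, a 1.1-fold higher number from compound 1 to compound 2 (0.03 log units; within the scatter), is within the scatter, so compound 1 and compound 2 cannot be told apart in this assay.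

Compound 3 is `COc1ccc(/C=C2/N=C(c3ccccc3)N(c3ccc4oc(-c5ccccc5)cc(=O)c4c3)C2=O)cc1OC`. The change from compound 2 is 3,4-dimethoxyphenyl in place of 3,4-dichlorophenyl on a double-bonded chain carbon bound to a double-bonded ring carbon. Going by the values given here, the one measured step that touches this position, a 1.1-fold higher number from compound 1 to compound 2 (0.03 log units; within the scatter), replaced a single methoxy-bearing ring by the dichloro ring and moved the number by less than the scatter. The change to compound 3 goes the other way, back to methoxy groups and adding a second one, so nothing measured here suggests that this position drives the number in either direction. The expected step is therefore a 1.0-fold lower number from compound 2 to compound 3 (0.02 log units; within the scatter), none beyond the scatter. Compound 3 is estimated at 14.5 ug/mL in this assay, with a range from 7 ug/mL to 30 ug/mL that reflects the uncertainty of a single untested change.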

Compound 3, half-maximal inhibitory concentration: 9.87 ug/mL
Beside the measured number, compound 3's estimate is 1.5-fold (0.17 log units) above it; the measured number falls inside the stated range.
By their numbers in this assay, from the lowest: compounds 3, 1 and 2 (each within the scatter of the next).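

In this assay the full swap of the two chlorines for two methoxy groups gives a 1.5-fold lower number from compound 2 to compound 3 (0.19 log units; within the scatter) and the single added methoxy gives a 1.4-fold lower number from compound 1 to compound 3 (0.16 log units; within the scatter), so the 3,4-dimethoxyphenyl group cannot be told apart from either the 3,4-dichlorophenyl or the 4-methoxyphenyl group at this place. For the compounds shown here, the earlier compounds tested only one exchange here, whereas these three now form a closed set in which no step between any pair stands beyond the scatter, even though the entering 3,4-dimethoxyphenyl group brings hydrogen-bond acceptors that the 3,4-dichlorophenyl group lacks. No measurement at hand bears on why the numbers stay so close.

Still open is whether an amine or a carboxylic acid on this aromatic ring would move the number beyond the scatter, as all three aryl groups shown carry only chloro or methoxy substituents. Also open, going by these compounds, is whether a longer chain in place of the ring on the double-bonded chain carbon would separate from these compounds, or whether changes elsewhere on the shared core would count for more than any change at this place.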